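The source may report more compounds than this note shows. Statements on the series, on what has been measured and on what is new or still open speak of the compounds shown alone.

Measured compounds:
Compound 1, `O=S(=O)(c1ccc(F)c(F)c1)c1cnc2cc(F)ccc2c1-c1ccc(Cl)cc1`, 0.01 mL/min in an ADME assay on microsomes from liver (Homo sapiens) for metabolic stability, tested at 2.5 uM; on this read-out lower numbers stand for slow clearance and higher numbers for fast clearance.
Compound 2, `O=S(=O)(c1ccc(F)cc1)c1cnc2cc(F)ccc2c1-c1ccc(Cl)cc1`, 1.23 mL/min in this assay.

Compound 1 stands lowest of the two numbers; its nearest neighbour is compound 2, reached by a 120-fold higher number from compound 1 to compound 2 (2.09 log units; beyond the scatter), a step made by a hydrogen in place of fluoro on an aromatic carbon. Compound 3, `O=S(=O)(c1ccc(F)c(F)c1)c1cnc2cc(F)ccc2c1-c1ccccc1F`, is not yet measured. It differs from compound 1 as follows: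

2-fluorophenyl in place of 4-chlorophenyl on an aromatic carbon

Going by the values given here, the one measured step concerns a different place in the shared core, so it does not bear directly on this change; it shows only that a single small change on one of the aromatic rings of compound 1 can move the number far beyond the scatter. Nothing measured tells how swapping one six-membered aromatic ring of carbon only for another, at the place described, acts in this assay. The expectation for compound 3 therefore rests on compound 1 alone and is held loosely: a modest rise is expected, as a 4.0-fold higher number from compound 1 to compound 3 (0.60 log units; beyond the scatter), with a wide range. Compound 3 is estimated at 0.04 mL/min, between 0.005 mL/min and 0.4 mL/min.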

Compound 3, intrinsic clearance in a liver preparation (reported as CLH), per the amount of preparation that the assay uses: 0.79 mL/min
Compound 3: the middle estimate sits 20-fold (1.30 log units) below what was measured; measured number above the stated range.
By their numbers in this assay, from the lowest: compound 1; then compounds 3 and 2 (each within the scatter of the next).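

In this assay, the aromatic carbon opposite the ring nitrogen proves to be a place where a single change moves the number a long way: 2-fluorophenyl in place of 4-chlorophenyl gives a 79-fold higher number from compound 1 to compound 3 (1.90 log units; beyond the scatter), although both groups hold the same count of heavy atoms and one six-membered aromatic ring of carbon only. The earlier step, a 120-fold higher number from compound 1 to compound 2 (2.09 log units; beyond the scatter), lay in another place, so the low number of compound 1 is now seen to give way to a large rise on a change at either of two separate places, and neither listed step from compound 1 goes the other way. Nothing measured on these compounds offers an explanation for this rise.

Since the halogen and its place on the ring change together in this step, the compounds shown cannot say which of the two carries the rise, and 2-chlorophenyl or 4-fluorophenyl at this position would separate them. They also leave open how this position responds to a group of another kind, such as an amine or a methoxy group, in place of the halogen-bearing ring.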